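A Hydroxyl in Place of Methoxy on the Tail

This account rests on a few compounds, and the source may have more. Where it says the series, first, only, none or still open, it means among the compounds named here.

Compound 1, `CC(C)C[C@H](N)c1cc(C(F)(F)F)ccc1N1CCN(C(=O)CCc2ccccc2Cl)CC1`, in an assay on HEK293 cells for displacement of a labelled ligand from Melanocortin receptor 4 (Homo sapiens) (on this read-out higher numbers stand for weaker inhibition and lower numbers for stronger inhibition), gives 1700 nM.
Compound 2, `Cc1cccc(CCC(=O)N2CCN(c3ccc(C(F)(F)F)cc3[C@@H](N)CC(C)C)CC2)c1`, in this assay gives 2100 nM.
Compound 3, `COc1cccc(CCC(=O)N2CCN(c3ccc(C(F)(F)F)cc3[C@@H](N)CC(C)C)CC2)c1`, in this assay gives 4000 nM.

Compound 3 carries the highest of the three numbers: a 2.4-fold higher number from compound 1 to compound 3 (0.37 log units; beyond the scatter), while a 1.9-fold higher number from compound 2 to compound 3 (0.28 log units; within the scatter). Compound 4, `CC(C)C[C@H](N)c1cc(C(F)(F)F)ccc1N1CCN(C(=O)CCc2ccc(O)cc2)CC1`, differs from compound 3 in one place: 4-hydroxyphenyl in place of 3-methoxyphenyl on a saturated chain carbon, two bonds along the chain from a carbonyl carbon. The three measured steps all swap one group on the same phenyl ring, and none moved the number far: a 1.2-fold higher number from compound 1 to compound 2 (0.09 log units; within the scatter), a 2.4-fold higher number from compound 1 to compound 3 (0.37 log units; beyond the scatter), a 1.9-fold higher number from compound 2 to compound 3 (0.28 log units; within the scatter). On that basis compound 4 is expected to stay close to compound 3 in this assay, with no step beyond the scatter, a 1.3-fold lower number from compound 3 to compound 4 (0.12 log units; within the scatter). The estimate for compound 4 is 3000 nM, within 1000 nM to 9000 nM.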

Compound 4, inhibition constant: > 10000 nM
Compound 4: only a limit was reported; the forecaster's own chance of this, stated with the estimate: 5%; middle value at least 3.3-fold (0.52 log units) away from the limit.
By their numbers in this assay, from the lowest: compounds 1, 2 and 3 (each within the scatter of the next, the first and the last beyond it). At a limit, above all of these: compound 4.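

Compound 4 gives > 10000 nM in this assay, which is a limit of the assay and not a number. The swaps among compounds 1, 2 and 3 kept measurable values, but the 4-hydroxyphenyl tail does not, with an at least 2.5-fold higher number from compound 3 to compound 4 (0.39 log units; beyond the scatter), an at least 4.7-fold higher number from compound 2 to compound 4 (0.67 log units; beyond the scatter) and an at least 5.8-fold higher number from compound 1 to compound 4 (0.76 log units; beyond the scatter). So this position does not accept every substituted phenyl, and the true size of these steps stays unknown.

The change replaces methoxy with hydroxyl and also shifts the ring position of the oxygen, and the compounds shown cannot separate those two effects. From the compounds shown here alone, how an amine or a carboxylic acid on this phenyl ring would behave also stays open.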